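The source may hold more compounds than are shown below. What is called first, only, known or untested is meant among the compounds shown, and "the series" means these compounds.

Among the measured compounds shown here, compound 3 `COc1ccc(C2N=C(SCc3ccccc3Cl)NC(C)=C2C(=O)Nc2ccc(Br)cc2)cc1` gives 17.9% in a functional assay on the whole organism (artery, strain albino) with Rattus norvegicus as the target, with a stated time of 300 min, at a dose of 10 mg/kg by the oral route (a higher number here means more inhibition at the dose given (going by the name of the read-out), a lower number less inhibition), the lowest of the three numbers so far. Compound 1 `CC1=C(C(=O)Nc2ccc(Br)cc2)C(c2ccc(Cl)cc2Cl)N=C(SCc2ccccc2Cl)N1` gives 36.4% and compound 2 `CC1=C(C(=O)Nc2ccc(Br)cc2)C(c2ccc(Cl)cc2Cl)N=C(SCc2ccc(Cl)cc2)N1` gives 38.5% in this assay, so compound 3 sits apart from both, and the step of a number 18.5 percentage points lower from compound 1 to compound 3 (beyond the scatter) is beyond the scatter. Compound 4 `COc1ccc(C2N=C(SCc3ccc(Cl)cc3)NC(C)=C2C(=O)Nc2ccc(Br)cc2)cc1` is the unmeasured partner of compound 3: 4-chlorophenyl in place of 2-chlorophenyl on a saturated chain carbon bound to a sulfur. For the measured compounds named here, the same change has been measured once, as a number 2.1 percentage points higher from compound 1 to compound 2 (within the scatter), a difference within the scatter; no other step bears on it. No movement beyond the scatter is therefore expected, and the step of a number 2.1 percentage points higher from compound 3 to compound 4 (within the scatter) is estimated to be small. For compound 4 the expected value in this assay is 20%, with a range from 8% to 32%.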

Compound 4, a percentage reported as inhibition, in the whole organism at one dose (the size of the read-out at that dose, not a potency): 37.9%
Compound 4: middle estimate off by 17.9 percentage points, on the low side; the whole stated range lies below it.
By their numbers in this assay, from the lowest: compound 3; then compounds 1, 4 and 2 (each within the scatter of the next).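

The change from 2-chlorobenzyl to 4-chlorobenzyl gives a number 20 percentage points higher from compound 3 to compound 4 (beyond the scatter), so in this assay its size depends on the group on the saturated ring carbon: the same change on two cores in this assay, a number 2.1 percentage points higher (within the scatter) from compound 1 to compound 2 and a number 20 percentage points higher (beyond the scatter) from compound 3 to compound 4, 17.9 percentage points apart, beyond the scatter of two such steps

With 4-chlorobenzyl present, 4-methoxyphenyl in place of 2,4-dichlorophenyl gives a number 0.6 percentage points lower from compound 2 to compound 4 (within the scatter), so the drop seen with compound 3 appears only alongside 2-chlorobenzyl: the same change on two cores in this assay, a number 18.5 percentage points lower (beyond the scatter) from compound 1 to compound 3 and a number 0.6 percentage points lower (within the scatter) from compound 2 to compound 4, 17.9 percentage points apart, beyond the scatter of two such steps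

Open, on these data alone, is whether this dependence holds with 3-chlorobenzyl, or with a longer chain or an amine in place of the chlorobenzyl group.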